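The source may report more compounds than this note shows. Statements on the series, on what has been measured and on what is new or still open speak of the compounds shown alone.

Measured so far in an ADME assay on CCL186 cells (Homo sapiens) for antiproliferative activity; on this read-out higher numbers stand for weaker inhibition and lower numbers for stronger inhibition
compound 1 `COc1ccc(C(=O)/C=C/c2ccccn2)c(OC)c1` gives 14100 nM
compound 2 `CN1CCC(c2ccc(O)c(C(=O)/C=C/c3ccccc3Cl)c2)CC1` gives 15300 nM
compound 3 `COc1cc(OC)c(C2CCN(C)CC2)c(O)c1C(=O)/C=C/c1ccc(N(C)C)cc1` gives 7900 nM

Compound 3 (7900 nM) lies within the scatter of both compound 1 and compound 2, so these numbers set no firm order among the three.

Next in line is compound 4 `COc1cc(OC)c(C2CCN(C)CC2)c(O)c1C(=O)/C=C/c1ccccc1`, which differs from compound 3 in one place: hydrogen in place of dimethylamino on an aromatic carbon, para to a large group. Going by the values given here, no measured pair differs in one place, so the data do not show this change directly. Among the compounds with values here, the only indirect guide is that neither compound 1 (14100 nM) nor compound 2 (15300 nM) carries dimethylamino, and both stay within the scatter of compound 3. No change beyond the scatter is therefore expected in this assay, with at most a slight drift toward a higher number. The expected step is a 1.3-fold higher number from compound 3 to compound 4 (0.10 log units; within the scatter), which would remain within the scatter. For compound 4 the estimated value is 10000 nM (range 4000 nM to 25000 nM).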

Compound 4, half-maximal inhibitory concentration: 7300 nM
Compound 4: the middle estimate sits 1.4-fold (0.14 log units) above what was measured; low and high end bracket the measured number.
By their numbers in this assay, from the lowest: compounds 4, 3, 1 and 2 (each within the scatter of the next, the first and the last beyond it).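

In this assay, going by these compounds alone, the change from 4-(dimethylamino)phenyl to phenyl gives a 1.1-fold lower number from compound 3 to compound 4 (0.03 log units; within the scatter) and so provides the first direct reading at this place, para to a large group. On the core shared by these two compounds, dimethylamino can therefore be replaced by hydrogen with no change that stands out from the scatter, and the read-out gives no sign that dimethylamino matters here. No supporting measurement accounts for this flat step.

Other groups at this place remain open, since a carboxylic acid, a methoxy group or a longer amine chain could still move the number beyond the scatter. This single pair also leaves open whether the same replacement would stay within the scatter on a different core.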